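This account rests on a few compounds, and the source may have more. Where it says the series, first, only, none or still open, it means among the compounds named here.

Measured compounds:
compound 1 `CC(C(=O)NCc1ccc(C(F)(F)F)nc1NCc1ccc(Cl)cc1)c1ccc(NS(C)(=O)=O)c(F)c1` gives 65.7 nM in a functional assay on CHO-K1 cells for antagonist activity at transient receptor potential cation channel subfamily V member 1 (Homo sapiens), read by FLIPR; a lower number here means a stronger inhibitor, a higher number a weaker inhibitor
compound 2 `CC(C(=O)NCc1ccc(C(F)(F)F)nc1N1CCN(C2CCCCC2)CC1)c1ccc(NS(C)(=O)=O)c(F)c1` gives 21.6 nM in this assay

Compound 2 holds the lower of the two numbers in this assay. Within the data shown here, the only measured step is a 3.0-fold lower number from compound 1 to compound 2 (0.48 log units; beyond the scatter), in which 4-cyclohexylpiperazin-1-yl replaced (4-chlorobenzyl)amino on an aromatic carbon of the shared core.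

Compound 3 `CC(C(=O)NCc1ccc(C(F)(F)F)nc1N1CCN(Cc2ccccc2)CC1)c1ccc(NS(C)(=O)=O)c(F)c1` is not yet measured. It differs from compound 2 by benzyl in place of cyclohexyl on an amine nitrogen in a ring. Among the measured compounds shown here, this change sits on the amine nitrogen of the six-membered non-aromatic ring with two nitrogens, a place that no measured step touches: the one step measured, from compound 1 to compound 2, altered the group on the aromatic carbon and so says nothing about what happens at the ring nitrogen. For the measured compounds named here, with no step bearing on this change, the account expects no step beyond the usual scatter, in either direction.

The estimate for compound 3 in this assay is therefore 25 nM, with a range from 8 nM to 80 nM, which corresponds to an expected step of a 1.2-fold higher number from compound 2 to compound 3 (0.06 log units; within the scatter).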

Compound 3, inhibition constant: 8.8 nM
Estimate against measurement, compound 3: 2.8-fold (0.45 log units) above, and the stated range covers the measured number.
By their numbers in this assay, from the lowest: compound 3; then compound 2; then compound 1.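

In this assay, among these compounds, the amine nitrogen in the six-membered non-aromatic ring proves to be a place where the group matters: benzyl in place of cyclohexyl gives a 2.5-fold lower number from compound 2 to compound 3 (0.39 log units; beyond the scatter), the first measured step at this nitrogen. The counts under comparison are narrow, since the leaving and entering groups both have no hydrogen-bond donors, no hydrogen-bond acceptors and no net charge, and they differ in a six-membered aromatic ring replacing a non-aromatic one and in 7 heavy atoms replacing 6, so this single step cannot separate the aromatic ring from the added carbon. No measurement among those shown bears on why the number falls with this change.

The compounds shown leave open whether the carbon linking the aromatic ring to the amine nitrogen is needed, which a phenyl group directly on that nitrogen or a longer chain such as phenylethyl would address. They also leave open how the step would respond to a chlorine or methoxy group on the benzyl ring, or to an open-chain alkyl group in its place.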